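Aryl ring variation in a diarylpropyl guanidine series

The source may report more compounds than this note shows. Statements on the series, on what has been measured and on what is new or still open speak of the compounds shown alone.

Working notes on four analogues sharing one core. Compound 1 `N=C(NCCCc1c[nH]cn1)NCCC(c1ccccc1)c1ccccn1` gives 0.7 in a functional assay on muscle tissue for agonist activity at histamine H2 receptor (Cavia porcellus); on this read-out lower numbers stand for smaller maximal responses and higher numbers for larger maximal responses. Compound 2 `N=C(NCCCc1c[nH]cn1)NCCC(c1ccc(Cl)cc1)c1ccccn1` gives 0.8 in this assay, and compound 3 `N=C(NCCCc1c[nH]cn1)NCCC(c1cccc(C(F)(F)F)c1)c1ccccn1` gives 0.7 in this assay. Compound 3 stands level with compound 1 at the digits shown, the two together being the lowest of the three numbers; its nearest neighbour is compound 1, its furthest is compound 2, and a number 0.10 lower from compound 2 to compound 3 (within the scatter) lies within the scatter.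

Compound 4 `N=C(NCCCc1c[nH]cn1)NCCC(c1cc(F)cc(F)c1)c1ccccn1` has not yet been measured. It differs from compound 3 by 3,5-difluorophenyl in place of 3-(trifluoromethyl)phenyl on a saturated chain carbon bound to an aromatic carbon and a saturated chain carbon.

The measured steps that bear on this change all vary the same aryl ring: a number 0.10 higher from compound 1 to compound 2 (within the scatter), no change at the digits printed from compound 1 to compound 3 (within the scatter) and a number 0.10 lower from compound 2 to compound 3 (within the scatter), every one within the scatter. Among these three compounds, changing the substituent on that ring has produced no step beyond the scatter. On this basis the expected step is no change at the digits printed from compound 3 to compound 4 (within the scatter), none beyond the scatter. Compound 4 is estimated at 0.7 in this assay, with a range from 0.6 to 0.8.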

Compound 4, intrinsic activity: the largest response reached, as a fraction of the reference agonist's: 0.8
Beside the measured number, compound 4's estimate is 0.10 below it; the measured number falls inside the stated range.
By their numbers in this assay, from the lowest: compounds 1, 3, 2 and 4 (each within the scatter of the next).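

At the saturated chain carbon bound to an aromatic carbon and a saturated chain carbon, 3,5-difluorophenyl extends the aryl groups compared in this assay to one bearing fluorine in two places, and all three new comparisons lie within the scatter (a number 0.10 higher from compound 3 to compound 4 (within the scatter); no change at the digits printed from compound 2 to compound 4 (within the scatter); a number 0.10 higher from compound 1 to compound 4 (within the scatter)). Phenyl, 4-chlorophenyl, 3-(trifluoromethyl)phenyl and 3,5-difluorophenyl are therefore not separated by this read-out, so the four compounds give no ranking of these aryl groups. No supporting data are available to explain this outcome.

Going by these compounds, whether an amine or a carboxylic acid on this aryl ring would produce a step beyond the scatter remains open. Also open, on these data alone, is whether a saturated cyclohexyl group in place of the aryl ring, or a longer chain in the shared core, would do so.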